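Notes on the step from compound 3 to compound 4

The source may report more compounds than this note shows. Statements on the series, on what has been measured and on what is new or still open speak of the compounds shown alone.

Values so far in a physicochemical assay for lipophilicity; on this read-out lower numbers stand for lower lipophilicity and higher numbers for higher lipophilicity
compound 1 `C[C@H]1CC[C@@H]2[C@@H](OC(=O)[C@]23CC(c2ccccc2Br)=NO3)[C@]2(C)C(=O)C=C[C@@]12O` at 2.22
compound 2 `COc1cc(C2=NO[C@]3(C2)C(=O)O[C@@H]2[C@H]3CC[C@H](C)[C@]3(O)C=CC(=O)[C@@]23C)ccc1O` at 0.75
compound 3 `C[C@H]1CC[C@@H]2[C@@H](OC(=O)[C@]23CC(c2cccc([N+](=O)[O-])c2)=NO3)[C@]2(C)C(=O)C=C[C@@]12O` at 1.37

Compound 3 stands second highest of the three values, with a number 0.85 log units lower from compound 1 to compound 3 (beyond the scatter) and a number 0.62 log units higher from compound 2 to compound 3 (beyond the scatter) marking its gaps to the other two. Compound 4 `C[C@H]1CC[C@@H]2[C@@H](OC(=O)[C@]23CC(c2ccc(F)cc2)=NO3)[C@]2(C)C(=O)C=C[C@@]12O` has not been measured. The change is 4-fluorophenyl in place of 3-nitrophenyl on a carbon with a double bond to nitrogen, counted as 4-fluorophenyl in place of 3-nitrophenyl on a carbon with a double bond to nitrogen and leaving the shared core untouched. All three measured steps are swaps at this same place, and a number 1.47 log units lower from compound 1 to compound 2 (beyond the scatter) is the largest of them. Within the data shown here, no measured compound carries 4-fluorophenyl. Compound 4 shares a halogen-bearing phenyl with compound 1 at 2.22 and loses the nitro group of compound 3 at 1.37, so a modest rise in this assay is expected. The estimated move is a number 0.38 log units higher from compound 3 to compound 4 (beyond the scatter) and would fall short of the full gap to compound 1. For compound 4 the estimated value is 1.75 with 1.4 to 2.1 as the expected range.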

Compound 4, partition coefficient: 1.58
Estimate against measurement, compound 4: 0.17 log units above, and the stated range covers the measured number.
By their numbers in this assay, from the lowest: compound 2; then compounds 3 and 4 (each within the scatter of the next); then compound 1.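

In this assay, a number 0.21 log units higher from compound 3 to compound 4 (within the scatter), so at this position 4-fluorophenyl and 3-nitrophenyl cannot be told apart, even though the two groups share no substituent. A halogen on the phenyl does not by itself give a value like that of compound 1, with a number 0.64 log units lower from compound 1 to compound 4 (beyond the scatter), while the 4-hydroxy-3-methoxyphenyl group stays clearly separate, with a number 0.83 log units higher from compound 2 to compound 4 (beyond the scatter). No measurement on hand accounts for these gaps.

2-Bromophenyl and 4-fluorophenyl differ in both the halogen and its place on the ring, and the compounds shown do not separate these two changes. Also open, from the compounds shown here alone, is how a phenyl carrying an amine or a carboxylic acid would read in this assay.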